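The source may hold more compounds than are shown below. What is called first, only, known or untested is meant among the compounds shown, and "the series" means these compounds.

For the measured compounds named here, in a functional assay on HCT-116 cells (Homo sapiens) for inhibition, read by CCK-8 assay, with a stated time of 48 h (on this read-out lower numbers stand for stronger inhibition and higher numbers for weaker inhibition), compound 1 `COc1cc(-c2ccnc3cc(-c4ccc(C)cc4)nn23)cc(OC)c1OC` gives 48 nM, the lowest of the three numbers measured so far. Compound 2 `COc1cc(-c2ccnc3cc(-c4cn(C)c5ccccc45)nn23)cc(OC)c1OC` gives 762 nM, and compound 3 `COc1cc(-c2ccnc3cc(-c4cccc(C)c4)nn23)cc(OC)c1OC` gives 6150 nM. Compound 4 `COc1cc(-c2ccnc3cc(-c4ccc(-c5cnn(C)c5)cc4)nn23)cc(OC)c1OC` keeps the core of compound 1 and differs in one place: 1-methyl-1H-pyrazol-4-yl in place of methyl on an aromatic carbon. Going by the values given here, no measured step makes this exact change, but two steps replace the whole 4-methylphenyl group, and they show a 16-fold higher number from compound 1 to compound 2 (1.20 log units; beyond the scatter) and a 130-fold higher number from compound 1 to compound 3 (2.11 log units; beyond the scatter). Both moved the number upward, though neither is a direct guide, as compound 4 keeps the six-membered ring. The expected result in this assay is therefore a smaller upward move, estimated as a 3.8-fold higher number from compound 1 to compound 4 (0.57 log units; beyond the scatter). For compound 4 the estimated value is 180 nM, with an expected range from 30 nM to 1000 nM.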

Compound 4, half-maximal inhibitory concentration: 2110 nM
Estimate against measurement, compound 4: 12-fold (1.07 log units) below; measured number outside the range, above it.
By their numbers in this assay, from the lowest: compound 1; then compound 2; then compound 4; then compound 3.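

Keeping the six-membered ring does not preserve the low number: in this assay, the change at this position alone gives a 44-fold higher number from compound 1 to compound 4 (1.64 log units; beyond the scatter), so the earlier whole-group replacements were not the only kind of change that raises it. On this ring, para to a large group, a methyl and a 1-methyl-1H-pyrazol-4-yl therefore give clearly different results. Nothing measured here explains the rise.

As far as these compounds go, it remains open whether the larger group or its nitrogen atoms matter more. An ethyl, a methoxy or an amine at this position would help separate the two.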